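This account rests on a few compounds, and the source may have more. Where it says the series, first, only, none or still open, it means among the compounds named here.

Two esters of a shared core were tested in a functional assay on MCF7 cells (Homo sapiens) for antiproliferative activity, read by sulforhodamine B assay, with a stated time of 48 h, tested at 50 uM; on this read-out higher numbers stand for more inhibition at the one concentration tested (going by the name of the read-out) and lower numbers for less inhibition. Compound 1 `COc1cccc(C(=O)Oc2cc3c(cc2C)[C@@H](C(C)C)CC=C3C)c1` gives 11.9%, while compound 2 `CC1=CC[C@H](C(C)C)c2cc(C)c(OC(=O)c3ccc(C(F)(F)F)cc3)cc21` gives 40.4%; compound 2 thus stands highest of the two, beyond the scatter from compound 1. Compound 3 `CC1=CC[C@H](C(C)C)c2cc(C)c(OC(=O)c3ccc(Cl)cc3)cc21` has not yet been measured. It differs from compound 2 only in one place: chloro in place of trifluoromethyl on an aromatic carbon. Within the data shown here, with no measured step of this kind to lean on, the estimated step from compound 2 to compound 3 is a number 7.4 percentage points lower from compound 2 to compound 3 (within the scatter), a small drop that may well lie within the scatter. Compound 3 is therefore expected to give about 33%, in a range from 16% to 50%.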

Compound 3, a percentage reported as inhibition, at one concentration (the size of the read-out at that concentration, not a potency): 79.7%
Beside the measured number, compound 3's estimate is 46.7 percentage points below it; measured number above the stated range.
By their numbers in this assay, from the lowest: compound 1; then compound 2; then compound 3.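

Chloro in place of trifluoromethyl, on an aromatic carbon para to a large group, brings a number 39.3 percentage points higher from compound 2 to compound 3 (beyond the scatter) in this assay, so the read-out responds strongly to this single place. With 4-chlorophenyl in place of 3-methoxyphenyl on a carbonyl carbon, there is a number 67.8 percentage points higher from compound 1 to compound 3 (beyond the scatter). Nothing shown here accounts for these gains.

From the compounds shown here alone, how a bromo, a nitrile or an amine at this place would compare remains open. So does how compound 3 would behave at concentrations other than the single one tested.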